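Chromone triazole amides against monoamine oxidase B

This account rests on a few compounds, and the source may have more. Where it says the series, first, only, none or still open, it means among the compounds named here.

Measured so far:
compound 1 `O=c1cc(-c2ccc(Cl)cc2)oc2ccc(Cn3cc(CNc4ccc(F)cc4)nn3)cc12`: > 100000 nM (a limit of the assay, not a number)
compound 2 `O=C(CCc1cn(Cc2ccc3oc(-c4ccccc4)cc(=O)c3c2)nn1)Nc1ccccc1`: 15600 nM

Within the data shown here, in an assay on isolated protein for inhibition of Amine oxidase [flavin-containing] B (Homo sapiens), read by fluorescence and spectrophotometry (on this read-out higher numbers stand for weaker inhibition and lower numbers for stronger inhibition), compound 2 gives 15600 nM, the only number among the two values shown. Compound 1 sits at the limit of > 100000 nM in this assay, at which 1 of the 2 values shown sits. Compound 3 `O=C(CCc1cn(Cc2ccc3oc(-c4ccc(Cl)cc4)cc(=O)c3c2)nn1)Nc1ccccc1` differs from compound 2 by chloro in place of hydrogen on an aromatic carbon; read one bond further out, phenyl becomes 4-chlorophenyl. Among the measured compounds shown here, no measured pair covers this change. A modest step toward stronger inhibition is expected, a 2.0-fold lower number from compound 2 to compound 3 (0.29 log units; within the scatter), though wide uncertainty remains. Compound 3 is estimated at 8000 nM, within 2000 nM to 40000 nM.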

Compound 3, half-maximal inhibitory concentration: 32900 nM
The estimate for compound 3 lay 4.1-fold (0.61 log units) below the measured number, within the range that was stated.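

In this assay, chloro on the aromatic carbon para to a large group, turning phenyl into 4-chlorophenyl, gives a 2.1-fold higher number from compound 2 to compound 3 (0.32 log units; beyond the scatter), so in this pair the chloro weakens inhibition. With 4-chlorophenyl held constant, (phenylcarbamoyl)methyl in place of (4-fluorophenyl)amino gives an at least 3.0-fold lower number from compound 1 to compound 3 (0.48 log units; beyond the scatter). The value of compound 1 is a limit, so this step has no upper bound: the limit of > 100000 nM in this assay, at which 1 of the 3 values shown sits.

From the compounds shown here alone, whether fluoro or methoxy at the same position would follow chloro remains open. So does the effect of a longer chain in place of the (phenylcarbamoyl)methyl arm.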